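This account rests on a few compounds, and the source may have more. Where it says the series, first, only, none or still open, it means among the compounds named here.

Among the measured compounds shown here, compound 2, `Oc1ccc(C2=NN(c3ccc(Cl)cc3)C(c3cccc(Cl)c3)C2)cc1`, is one of two compounds measured in an assay on HEK293 cells for inhibition of protein kinase C iota type (Homo sapiens), read by 33P incorporation, with a stated time of 40 min, tested at 20 uM, in the presence of a further agent that is not named here (on this read-out lower numbers stand for less inhibition and higher numbers for more inhibition at the one concentration tested (going by the name of the read-out)), and in this assay compound 2 gives 18.6%. The other measured compound, compound 1, `Oc1ccc(C2=NN(c3ccc(Cl)cc3)C(c3ccc(Cl)cc3)C2)c(O)c1`, gives 14.9% in this assay. The gap between these two numbers lies within the usual scatter of repeated measurements, so neither compound can be set apart from the other on what has been measured so far. Compound 3, `Oc1ccc(C2=NN(c3cccc(Cl)c3)C(c3cccc(Cl)c3)C2)cc1`, has not yet been measured. It differs from compound 2 in one place: 3-chlorophenyl in place of 4-chlorophenyl on an amine nitrogen in a ring. For the measured compounds named here, no step between measured compounds of this kind is known. Both measured values are low, and nothing in them points toward a change in either direction, so the expected step of a number 1.6 percentage points lower from compound 2 to compound 3 (within the scatter) is small, not beyond the scatter. Compound 3 is therefore expected to give about 17% in this assay, with a range from 5% to 32%.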

Compound 3, a percentage reported as inhibition, at one concentration (the size of the read-out at that concentration, not a potency): 29%
Estimate against measurement, compound 3: 12 percentage points below; low and high end bracket the measured number.
By their numbers in this assay, from the lowest: compounds 1 and 2 (each within the scatter of the next); then compound 3.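

Swapping 4-chlorophenyl for 3-chlorophenyl on the amine nitrogen in the ring leaves the atoms unchanged and alters only how they are joined, yet this assay records a number 10.4 percentage points higher from compound 2 to compound 3 (beyond the scatter) as a modest change. The earlier compounds shown here, whose numbers lie within the scatter of each other, gave no sign of this: the reading at this position responds to where the chlorine sits on the phenyl ring. Nothing measured here explains why this happens.

Going by these compounds, whether other groups at this place, such as an unsubstituted phenyl, a pyridine ring or a benzyl group, would raise or lower the number remains open. So does whether the same swap would give a similar step with a methoxy group or an amine in place of the hydroxyl of the 4-hydroxyphenyl group.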